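Swapping the aryl on the ring nitrogen: compound 3 foreseen

The compounds below may be only part of what the source reports. "The series", "measured", "known", "first", "only" and "open" are said of these compounds alone.

Measured so far:
- compound 1, `Cc1cc(=O)n(-c2ccccc2OC(F)(F)F)nc1C(=O)Nc1ccc(Oc2ncnc3[nH]ccc23)cc1`: 32000 nM
- compound 2, `Cc1cc(=O)n(-c2ccc(Br)cc2F)nc1C(=O)Nc1ccc(Oc2ncnc3[nH]ccc23)cc1`: 3210 nM

In a functional assay on MCF7 cells (Homo sapiens) for cytotoxicity, read by MTT assay, with a stated time of 72 h (on this read-out lower numbers stand for stronger inhibition and higher numbers for weaker inhibition), compound 1 gives 32000 nM, and compound 2 gives 3210 nM. Compound 2 therefore has the lowest number of the two, with the step of a 10-fold lower number from compound 1 to compound 2 (1.00 log units; beyond the scatter) separating it from compound 1. Compound 3, `Cc1cc(=O)n(-c2cccc(C(F)(F)F)c2)nc1C(=O)Nc1ccc(Oc2ncnc3[nH]ccc23)cc1`, keeps the shared core and changes only the group on the aromatic nitrogen: 3-(trifluoromethyl)phenyl in place of 4-bromo-2-fluorophenyl on an aromatic nitrogen. Within the data shown here, the single measured step bears on this change, since it too replaced the aryl on that nitrogen, and it was modest but beyond the scatter. Among the measured compounds shown here, with only one such step, the direction for a third aryl cannot be read off, so the expectation for compound 3 is a number somewhere between the two measured ones, with a wide range. Compound 3 is estimated at 8000 nM (range 2000 nM to 32000 nM), which would mean an expected step of a 2.5-fold higher number from compound 2 to compound 3 (0.40 log units; beyond the scatter).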

Compound 3, half-maximal inhibitory concentration: 4560 nM
Compound 3: the middle estimate sits 1.8-fold (0.24 log units) above what was measured; the measured number falls inside the stated range.
By their numbers in this assay, from the lowest: compounds 2 and 3 (each within the scatter of the next); then compound 1.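

In this assay the swap of the aryl group on the ring nitrogen now gives a 1.4-fold higher number from compound 2 to compound 3 (0.15 log units; within the scatter) so two differently substituted aryl groups at this position cannot be told apart. Compound 1 remains separate from both, with the change to 3-(trifluoromethyl)phenyl giving a 7.0-fold lower number from compound 1 to compound 3 (0.85 log units; beyond the scatter) so the earlier gap was not unique to the 4-bromo-2-fluorophenyl group. No measurement shown here explains how these aryl groups differ or match in their effect on the cells.

From the compounds shown here alone, the three compounds cover only halogen-bearing or fluorine-containing aryl groups, so the effect of a phenyl ring with no substituent remains open. It is also unknown how an aryl group carrying an amine or a carboxylic acid would compare at this nitrogen.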